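Growing the alkyl chain on the shared core

A few compounds are considered here, and "the series" means these few. Any claim that something is new, unique, unknown or untested is made for them only; others in the source may bear on it.

Compound 1, `COC(=O)c1nc(C)n(-c2ccccc2)n1`: in a functional assay on Jurkat cells (Homo sapiens) for inhibition, read by MTT assay, with a stated time of 72 h (on this read-out higher numbers stand for weaker inhibition of growth and lower numbers for stronger inhibition of growth), compound 1 gives > 100000 nM, which is a limit of the assay and not a number.
Compound 2, `COC(=O)c1nc(C)n(-c2ccc(F)cc2)n1`: in this assay compound 2 gives 8700 nM.
Compound 3, `CCc1nc(C(=O)OC)nn1-c1ccc(F)cc1`: in this assay compound 3 gives 11000 nM.

Compound 3 holds the highest of the two numbers shown, but the step of a 1.3-fold higher number from compound 2 to compound 3 (0.10 log units; within the scatter) is within the scatter, so compound 2 and compound 3 cannot be told apart. Among the measured compounds shown here, the only large step in the set is an at least 11-fold lower number from compound 1 to compound 2 (1.06 log units; beyond the scatter), and it rests on a limit: the limit of > 100000 nM in this assay, at which 1 of the 3 values shown sits.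

Compound 4, `CCCCc1nc(C(=O)OC)nn1-c1ccc(F)cc1`, differs from compound 3 by ethyl in place of hydrogen on a saturated chain carbon, two bonds along the chain from an aromatic carbon. For the measured compounds named here, the step that bears on this change is the one from compound 2 to compound 3, where the same chain grew by one carbon and the number barely moved (a 1.3-fold higher number from compound 2 to compound 3 (0.10 log units; within the scatter)). Going by the values given here, no measured step covers a longer extension of this chain, so the direction of any further effect cannot be read from the data. The expected step is therefore a 1.1-fold higher number from compound 3 to compound 4 (0.04 log units; within the scatter), that is, nothing beyond the scatter. Compound 4 is estimated to give 12000 nM in this assay, within a range from 4000 nM to 40000 nM.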

Compound 4, concentration for 50% growth inhibition: > 100000 nM
Compound 4 gave a limit, no number; the forecaster's own chance of this, stated with the estimate: 10%; at least 8.3-fold (0.92 log units) between middle value and limit.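

Unlike the earlier step on this chain, where compound 2 and compound 3 could not be told apart, lengthening it further has a clear effect in this assay: the move from ethyl to butyl gives an at least 9.0-fold higher number from compound 3 to compound 4 (0.95 log units; beyond the scatter). Measured against the methyl chain, the same picture holds, with an at least 11-fold higher number from compound 2 to compound 4 (1.06 log units; beyond the scatter). Compound 4 stands at a limit of the assay and not at a number, so these steps show how large the loss of growth inhibition is only from one side: the limit of > 100000 nM in this assay, at which 2 of the 4 values shown sit.

The compounds shown leave open how the effect builds along the chain, since a propyl group at this place could show whether growth inhibition fades gradually or drops off suddenly, and a still longer chain could show nothing new only if it stayed at the same limit. They also leave open whether length alone matters, which a butyl chain ending in an amine or a carboxylic acid would help to test, and whether the butyl chain has the same effect when the fluoro group is replaced by hydrogen.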